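Chloro for fluoro on the (2-fluorophenyl)amino group

The compounds below may be only part of what the source reports. "The series", "measured", "known", "first", "only" and "open" are said of these compounds alone.

Measured so far:
- compound 1 `COc1ccc(Nc2nc(-c3cccc(F)c3)nc3ccc(F)cc23)cc1`: in a functional assay on HT29-AK cells (Homo sapiens) for cytotoxicity, read by MTT assay, with a stated time of 48 h (on this read-out lower numbers stand for stronger inhibition and higher numbers for weaker inhibition), compound 1 gives 42300 nM.
- compound 2 `COc1ccccc1Nc1nc(-c2cccc(F)c2)nc2ccc(F)cc12`: in this assay compound 2 reaches only the assay limit, > 50000 nM.
- compound 3 `Fc1cccc(-c2nc(Nc3ccccc3F)c3cc(F)ccc3n2)c1`: in this assay compound 3 likewise gives only the limit, > 50000 nM.

Compound 3 therefore stands at the limit, as summed up by the limit of > 50000 nM in this assay, at which 2 of the 3 values shown sit, and compound 1 alone returns a number. From that number, an at least 1.1-fold higher number from compound 1 to compound 3 (0.07 log units; that floor lies within the scatter) and an at least 1.1-fold higher number from compound 1 to compound 2 (0.07 log units; that floor lies within the scatter), both floors within the scatter. Between the two limits, a step that the two limits leave unreadable from compound 2 to compound 3.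

Compound 4 `Fc1cccc(-c2nc(Nc3ccccc3Cl)c3cc(F)ccc3n2)c1` differs from compound 3 by chloro in place of fluoro on an aromatic carbon. Going by the values given here, no measured step exchanges one halogen for another on this ring, and none of the three measured steps is readable beyond the scatter, so for this assay no step beyond the scatter is expected. Given that compound 3 sits at > 50000 nM, compound 4 is expected at 60000 nM (range 20000 nM to 200000 nM), most probably again reported only as a limit. The estimated step is a step that the limit leaves unreadable from compound 3 to compound 4.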

Compound 4, half-maximal inhibitory concentration: > 50000 nM
Compound 4 gave a limit, no number; the forecaster's own chance of this, stated with the estimate: 70%; the middle value is on the limit's open side.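

In this assay, chloro at this place, on an aromatic carbon ortho to a large group, leaves compound 4 with > 50000 nM, which is a limit and not a number. Going by these compounds alone, the steps from compound 2 and compound 3 to compound 4 cannot be read, and the only comparison with a measured number gives an at least 1.1-fold higher number from compound 1 to compound 4 (0.07 log units; that floor lies within the scatter). A second halogen at this place therefore adds no readable gain, and the series gathers further at one ceiling: the limit of > 50000 nM in this assay, at which 3 of the 4 values shown sit.

Left open is how far compound 3 and compound 4 lie beyond the limit, so the size of the fluoro-to-chloro exchange stays unknown. Also open, on these data alone, is whether an amine or a carboxylic acid at this place would return a number in this assay.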